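Methyl to methoxy on the anilino ring of the quinazoline series

This account rests on a few compounds, and the source may have more. Where it says the series, first, only, none or still open, it means among the compounds named here.

Two members of this series have been measured. Compound 2 `C=CC(=O)Nc1cccc(NC(=O)CSc2nc(Nc3cccc(C)c3)c3ccccc3n2)c1` gives 20900 nM in a functional assay on MGC-803 cells (Homo sapiens) for inhibition, read by MTT assay, with a stated time of 72 h (a higher number here means a weaker inhibitor, a lower number a stronger inhibitor), and compound 1 `C=CC(=O)Nc1cccc(NC(=O)CSc2nc(Nc3ccccc3F)c3ccccc3n2)c1` gives 26100 nM in this assay. Going by the values given here, the only measured step is a 1.2-fold lower number from compound 1 to compound 2 (0.10 log units; within the scatter), so compound 2 and compound 1 cannot be separated on the numbers in hand; compound 2 simply stands at one end of a pair that the scatter does not resolve.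

Compound 3 `C=CC(=O)Nc1cccc(NC(=O)CSc2nc(Nc3cccc(OC)c3)c3ccccc3n2)c1` differs from compound 2 by methoxy in place of methyl on an aromatic carbon. Among the compounds with values here, the one step that bears on this change is the exchange of the aryl group on the same nitrogen, a 1.2-fold lower number from compound 1 to compound 2 (0.10 log units; within the scatter), which stayed inside the scatter. Nothing measured points to a direction for a methyl to methoxy exchange at this position, and the only comparable variation at that ring moved the number by less than the scatter. Compound 3 is therefore expected to sit close to compound 2, with a step of about a 1.0-fold higher number from compound 2 to compound 3 (0.00 log units; within the scatter). The estimate for compound 3 in this assay is 21000 nM, with a range of 9000 nM to 48000 nM.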

Compound 3, half-maximal inhibitory concentration: 24200 nM
The estimate for compound 3 lay 1.2-fold (0.06 log units) below the measured number; the range from low to high includes it.
By their numbers in this assay, from the lowest: compounds 2, 3 and 1 (each within the scatter of the next).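

In this assay, methoxy in place of methyl on this aromatic carbon gives a 1.2-fold higher number from compound 2 to compound 3 (0.06 log units; within the scatter), so this exchange, which adds an oxygen and a hydrogen-bond acceptor by the count, does not separate the two compounds at this place on the ring. The second new step, a 1.1-fold lower number from compound 1 to compound 3 (0.03 log units; within the scatter), also stays within the scatter, so 3-methoxyphenyl, 3-methylphenyl and 2-fluorophenyl on that nitrogen now form a set of three that the numbers do not resolve, and the series has yet to show a substituent on this ring that moves the read-out beyond the scatter. No measurement is available that would account for this result.

Still open, as far as these compounds go, is whether an amine or a carboxylic acid on this aromatic carbon, or a longer chain such as ethoxy, would give a step beyond the scatter. From the compounds shown here alone, the three compounds differ only in the aryl group on that nitrogen, so what the acrylamide and the rest of the shared core contribute to the number in this assay also remains open.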